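A few compounds are considered here, and "the series" means these few. Any claim that something is new, unique, unknown or untested is made for them only; others in the source may bear on it.

Compound 1 `O=C(CCN1CCN(c2ccnc3cc(Cl)ccc23)CC1)N/N=C/c1c[nH]c2ccccc12`: 5700 nM
Compound 2 `O=C(CCN1CCN(c2ccnc3cc(Cl)ccc23)CC1)N/N=C/c1ccc(Cl)cc1`: 200 nM
Compound 3 `CC(C)Oc1ccc(/C=N/NC(=O)CCN2CCN(c3ccnc4cc(Cl)ccc34)CC2)cc1`: 3600 nM

In an ADME assay on cells (Splenocyte, Mus musculus, strain BALB/c) for cytotoxicity, read by thymidine incorporation, with a stated time of 24 h (on this read-out lower numbers stand for stronger inhibition and higher numbers for weaker inhibition), compound 3 gives the second highest of the three numbers; it sits close to compound 1, within the scatter, as a 1.6-fold lower number from compound 1 to compound 3 (0.20 log units; within the scatter) shows, and far from compound 2, as an 18-fold higher number from compound 2 to compound 3 (1.26 log units; beyond the scatter) shows. Compound 4 `O=C(CCN1CCN(c2ccnc3cc(Cl)ccc23)CC1)N/N=C/c1ccccc1O` differs from compound 3 by 2-hydroxyphenyl in place of 4-isopropoxyphenyl on a carbon with a double bond to nitrogen. Among the compounds with values here, no measured step swaps a 4-isopropoxyphenyl for a 2-hydroxyphenyl, so the closest guides are the large swing in an 18-fold higher number from compound 2 to compound 3 (1.26 log units; beyond the scatter) and the large swing in a 29-fold lower number from compound 1 to compound 2 (1.45 log units; beyond the scatter), which show that the group on this carbon can move the number strongly in either direction. Within the data shown here, with no direct precedent, a modest shift toward a lower number is expected for compound 4 in this assay, a 2.4-fold lower number from compound 3 to compound 4 (0.38 log units; beyond the scatter), with wide uncertainty. The estimate for compound 4 is 1500 nM, expected to lie between 300 nM and 7000 nM.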

Compound 4, half-maximal inhibitory concentration: 11500 nM
For compound 4 the middle estimate is 7.7-fold (0.88 log units) below the measured one, outside the stated range (above it).
By their numbers in this assay, from the lowest: compound 2; then compounds 3, 1 and 4 (each within the scatter of the next, the first and the last beyond it).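

In this assay, 2-hydroxyphenyl on this carbon gives a clear rise against two other groups (a 3.2-fold higher number from compound 3 to compound 4 (0.50 log units; beyond the scatter); a 58-fold higher number from compound 2 to compound 4 (1.76 log units; beyond the scatter)), yet no clear difference from 1H-indol-3-yl (a 2.0-fold higher number from compound 1 to compound 4 (0.30 log units; within the scatter)). A third group thus joins the high end, and among these four compounds, compound 2 with its 4-chlorophenyl stands alone at the low end. Nothing available gives a reason for these shifts. As far as these compounds go, whether an aminophenyl or a carboxyphenyl on this carbon would stay high or come down like compound 2 remains open.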